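The source may report more compounds than this note shows. Statements on the series, on what has been measured and on what is new or still open speak of the compounds shown alone.

Compound 2 `Cc1ccc(N(C)CC2CCC/C(=C\c3ccccc3)C2(O)c2ccccc2)cc1` was examined in a functional assay on the whole organism (strain Kunming) for inhibition, with Mus musculus as the target, in the writhing test, with stated times of 1 h and 15 min, at a dose of 200 mg/kg by the oral route (a higher number here means more inhibition at the dose given (going by the name of the read-out), a lower number less inhibition), where compound 2 gives 64.2%. Among the compounds with values here, the only other measured compound, compound 1 `CN(CC1CCC/C(=C\c2ccccc2)C1=O)c1ccccc1`, gives 69.7% in this assay, and the gap between the two values lies within the usual scatter of repeated measurements, so nothing separates compound 2 from compound 1 on these numbers. Compound 3 `Cc1cccc(N(C)CC2CCC/C(=C\c3ccccc3)C2(O)c2ccccc2)c1` has not yet been measured in this assay. It differs from compound 2 in one place: 3-methylphenyl in place of 4-methylphenyl on an amine nitrogen. Within the data shown here, no measured pair of compounds shows a change of this kind, so there is no step from which its size could be read. The expectation is therefore a step from compound 2 to compound 3 of a number 2.2 percentage points lower from compound 2 to compound 3 (within the scatter), not beyond the scatter in either direction. Compound 3 is accordingly expected to give about 62% in this assay, within a range from 45% to 78%.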

Compound 3, a percentage reported as inhibition, in the whole organism at one dose (the size of the read-out at that dose, not a potency): 70.6%
For compound 3 the middle estimate is 8.6 percentage points below the measured one; measured number inside the range.
By their numbers in this assay, from the lowest: compounds 2, 1 and 3 (each within the scatter of the next).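

In this assay, within the data shown here, 3-methylphenyl in place of 4-methylphenyl on an amine nitrogen gives a number 6.4 percentage points higher from compound 2 to compound 3 (within the scatter), the first step that can be read at this position. On this one step, the place of the methyl group on this aromatic ring does not separate the two compounds at the dose given, so either methylphenyl group is compatible with the read-out. Nothing at hand bears on the reason for this step.

The compounds shown leave open whether a different group on the same ring, such as 3-chlorophenyl or 3-methoxyphenyl, would produce a step beyond the scatter. They also leave open whether compound 2 and compound 3 would separate at other doses, as a read-out at one dose is not a potency.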